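Aziridinylquinone side chains: from acetyl to a hydroxy-methoxy chain

This account rests on a few compounds, and the source may have more. Where it says the series, first, only, none or still open, it means among the compounds named here.

Measured compounds:
Compound 1, `COCCC1=C(N2CC2)C(=O)C(CCOC)=C(N2CC2)C1=O`: 4.71
Compound 2, `CC(=O)C1=C(N2CC2)C(=O)C(C)=C(N2CC2)C1=O`: 3.48

Of the compounds shown here, two sharing the same core have been tested in a functional assay on L1210 cells (Mus musculus), with a stated time of 1 days; on this read-out higher numbers stand for higher potency (the scale is a negative logarithm) and lower numbers for lower potency. Compound 1, `COCCC1=C(N2CC2)C(=O)C(CCOC)=C(N2CC2)C1=O`, gives 4.71 in this assay. Compound 2, `CC(=O)C1=C(N2CC2)C(=O)C(C)=C(N2CC2)C1=O`, gives 3.48, the lower of the two numbers; compound 1 stands higher by a margin beyond the scatter. Within the data shown here, no pair differing in one place has been measured, so no single step is known.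

Compound 3, `COC(CO)C1=C(N2CC2)C(=O)C(C)=C(N2CC2)C1=O`, remains to be measured. It differs from compound 2 as follows: 2-hydroxy-1-methoxyethyl in place of acetyl on a double-bonded ring carbon. The side chain that enters carries a methoxy group, and compound 1, whose side chains also carry methoxy groups, gives 4.71 in this assay. On that basis compound 3 is expected to move upward from compound 2 in this assay, by an estimated step of a number 0.72 log units higher from compound 2 to compound 3 (beyond the scatter), which would lie beyond the scatter. Compound 3 is therefore estimated at 4.2 in this assay, within a range from 3.6 to 4.9.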

Compound 3, logarithm of the reciprocal of the active concentration, log(1/C): 5.27
Estimate against measurement, compound 3: 1.07 log units below, outside the stated range (above it).
By their numbers in this assay, from the lowest: compound 2; then compound 1; then compound 3.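

Among these compounds, the first single-place step falls at this position: in this assay, replacing acetyl with 2-hydroxy-1-methoxyethyl on a double-bonded ring carbon gives a number 1.79 log units higher from compound 2 to compound 3 (beyond the scatter), a large rise that shows the read-out depends strongly on what this ring carbon carries. The exchange is not a simple one, since the 3 heavy atoms of acetyl, with their double bond and single hydrogen-bond acceptor, give way to a chain of 5 heavy atoms with no double bond, 1 hydrogen-bond donor and 2 hydrogen-bond acceptors, so the step records all these differences at once. Among the compounds shown here, nothing available explains why this exchange raises the number so far.

On these data alone, what remains open is which part of the entering chain carries the step, the hydroxy group, the methoxy group or the two together, and a 2-hydroxyethyl or 1-methoxyethyl group at the same ring carbon would separate them. As far as these compounds go, it is also open whether the same rise would follow with an amine at the end of the chain or with a longer chain, such as 3-hydroxypropyl, in this position.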